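Capping the phenol: from hydroxy to ethoxy

The compounds below may be only part of what the source reports. "The series", "measured", "known", "first", "only" and "open" are said of these compounds alone.

Measured in a functional assay on LNCaP cells (Homo sapiens) for antiproliferative activity, read by sulforhodamine B assay; a lower number here means a stronger inhibitor, a higher number a weaker inhibitor:
compound 1 `CCCCCCCCCCCCCCCCCCNC(=O)[C@@H]1CSC(c2cccc(O)c2)N1`: 1700 nM
compound 2 `CCCCCCCCCCCCCCCCCCNC(=O)[C@@H]1CSC(c2ccc(O)cc2)N1`: 1600 nM

Compound 2 has the smaller of the two numbers, but the step of a 1.1-fold lower number from compound 1 to compound 2 (0.03 log units; within the scatter) lies within the scatter, so compound 1 and compound 2 cannot be told apart. Compound 3 `CCCCCCCCCCCCCCCCCCNC(=O)[C@@H]1CSC(c2ccc(OCC)cc2)N1` differs from compound 2 by ethyl in place of hydrogen on an oxygen on an aromatic ring. Among the compounds with values here, no measured step touches this change; the only step known, between 3-hydroxyphenyl and 4-hydroxyphenyl, stayed within the scatter. With nothing pointing either way, the expected step of no change at the digits printed from compound 2 to compound 3 (within the scatter) is none beyond the scatter. Compound 3 is therefore estimated at 1600 nM in this assay, between 600 nM and 4500 nM.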

Compound 3, half-maximal inhibitory concentration: 6100 nM
Beside the measured number, compound 3's estimate is 3.8-fold (0.58 log units) below it, and the stated range ends below it.
By their numbers in this assay, from the lowest: compounds 2 and 1 (each within the scatter of the next); then compound 3.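

Within the data shown here, putting ethyl on the oxygen is the first change here that clearly moves the number in this assay, giving a 3.8-fold higher number from compound 2 to compound 3 (0.58 log units; beyond the scatter), whereas moving the hydroxy group did not. The comparison with the other hydroxy compound points the same way, with a 3.6-fold higher number from compound 1 to compound 3 (0.55 log units; beyond the scatter), so at this position a free hydroxy and an ethoxy group can be told apart. Nothing available explains why the number rises.

On these data alone, whether methoxy or a longer chain such as butoxy would give a similar step remains open. Also open, as far as these compounds go, is how 3-ethoxyphenyl or an amine in place of the hydroxy would compare.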